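Swapping benzyl for a fused bicyclic arene on a cyanoguanidine

A few compounds are considered here, and "the series" means these few. Any claim that something is new, unique, unknown or untested is made for them only; others in the source may bear on it.

Measured so far:
compound 1, `CC1(C)Oc2ccc(C#N)cc2[C@@H](/N=C(\NC#N)NCc2ccccc2)[C@@H]1O`, 2400 nM
compound 2, `CC1(C)Oc2ccc(C#N)cc2[C@@H](NC(=O)c2ccccc2)[C@@H]1O`, 30 nM

In a functional assay (aorta) with Rattus norvegicus as the target (on this read-out higher numbers stand for weaker inhibition and lower numbers for stronger inhibition), compound 1 gives the higher of the two numbers, while compound 2 sits far lower, a gap well beyond the scatter. Compound 3, `CC1(C)Oc2ccc(C#N)cc2[C@@H](/N=C(\NC#N)Nc2ccc3c(c2)CCC3)[C@@H]1O`, is not yet measured. It differs from compound 1 in one place: 2,3-dihydro-1H-inden-5-yl in place of benzyl on an amine nitrogen. For the measured compounds named here, no measured pair shows this change, so its size is unknown. A modest move toward stronger inhibition is expected, a 3.0-fold lower number from compound 1 to compound 3 (0.48 log units; beyond the scatter), though a result within the scatter would not surprise. For compound 3 the estimate in this assay is 800 nM, with a range from 150 nM to 4000 nM.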

Compound 3, half-maximal inhibitory concentration: 41300 nM
Beside the measured number, compound 3's estimate is 52-fold (1.71 log units) below it; the measured number lies above the stated range.
By their numbers in this assay, from the lowest: compound 2; then compound 1; then compound 3.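

In this assay, 2,3-dihydro-1H-inden-5-yl in place of benzyl on this amine nitrogen gives a 17-fold higher number from compound 1 to compound 3 (1.24 log units; beyond the scatter), so the read-out depends strongly on the group at this position. The swap exchanges one carbon-only group for another, with no hydrogen-bond donors or acceptors on either side, so a large step needs no such group entering or leaving. Nothing available explains the step.

The compounds shown leave open whether the added five-membered ring or the loss of the benzyl carbon link matters more. A plain phenyl on the same amine nitrogen would separate the two.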